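The compounds below may be only part of what the source reports. "The series", "measured", "known", "first", "only" and "open" are said of these compounds alone.

Compound 1 `CCn1c(-c2ccccc2)nc2c(NC3CCC3)ncnc21` gives 6 nM in an assay on CHO cells for displacement of a labelled ligand from adenosine receptor A1 (Homo sapiens), read by scintillation counting, with a stated time of 3 h; a lower number here means a stronger inhibitor, a higher number a weaker inhibitor.
Compound 2 `CCn1c(-c2ccccc2)nc2c(NC3CCCC3)ncnc21` gives 3.9 nM in this assay.
Compound 3 `CCn1c(-c2ccccc2)nc2c(N)ncnc21` gives 31 nM in this assay.

Among the compounds with values here, of the three compounds measured so far, compound 3 has the highest number in this assay. The steps that lead to it are a 5.2-fold higher number from compound 1 to compound 3 (0.71 log units; beyond the scatter) and a 7.9-fold higher number from compound 2 to compound 3 (0.90 log units; beyond the scatter), while the step between the two ring-bearing compounds is a 1.5-fold lower number from compound 1 to compound 2 (0.19 log units; within the scatter). Every one of these measured steps changes the group on the nitrogen attached to the aromatic ring; the chain on the ring nitrogen is the same in all three compounds.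

Compound 4 `CCCn1c(-c2ccccc2)nc2c(N)ncnc21` differs from compound 3 in a different place: methyl in place of hydrogen on a saturated chain carbon, two bonds along the chain from an aromatic nitrogen. Within the data shown here, no measured step touches this chain, so the measured steps offer no direct guide to the size or direction of the change. With nothing in the data pointing either way, the expected step from compound 3 to compound 4 in this assay is no change at the digits printed from compound 3 to compound 4 (within the scatter), that is, no change beyond the scatter. Compound 4 is therefore estimated at 31 nM in this assay, with a range from 12 nM to 80 nM to allow for the lack of any comparable step.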

Compound 4, inhibition constant: 101 nM
Estimate against measurement, compound 4: 3.3-fold (0.51 log units) below; measured number above the stated range.
By their numbers in this assay, from the lowest: compounds 2 and 1 (each within the scatter of the next); then compound 3; then compound 4.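

Within the data shown here, the chain on the aromatic nitrogen, untouched by every earlier step, proves able to move the reading in this assay: lengthening ethyl to propyl gives a 3.3-fold higher number from compound 3 to compound 4 (0.51 log units; beyond the scatter), the first measured step at this position. Among these compounds, a single added methyl, on a saturated chain carbon, two bonds along the chain from an aromatic nitrogen, shifts the number towards a weaker inhibitor, so the group on the nitrogen attached to the aromatic ring is no longer the only place in these compounds where a change is seen to matter. Nothing available explains why this change has this effect.

On these data alone, this step is read only with hydrogen on the nitrogen attached to the aromatic ring, so it remains open whether propyl in place of ethyl would have a similar effect on the number with cyclobutyl or cyclopentyl there. As far as these compounds go, with only ethyl and propyl on this nitrogen, it also remains open whether the number would keep rising with a longer chain such as butyl, or how a shorter methyl or a branched isopropyl would compare.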